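Cyano in Place of Dimethylamino: Expected Outcome

The compounds below may be only part of what the source reports. "The series", "measured", "known", "first", "only" and "open" are said of these compounds alone.

Among the measured compounds shown here, compound 1 `COc1ccc(S(=O)(=O)N2CCc3cccc(-c4ccc(N(C)C)cc4)c32)cc1` is one of two compounds measured in a functional assay on MKN-45 cells (Homo sapiens) for inhibition, with a stated time of 72 h; on this read-out higher numbers stand for weaker inhibition and lower numbers for stronger inhibition. In this assay compound 1 gives 237 nM, the highest of the two numbers recorded. The other measured compound, compound 2 `COc1ccc(S(=O)(=O)n2ccc3cccc(-c4ccc(F)cc4)c32)cc1`, gives 170 nM in this assay, and the two values lie within the usual scatter of each other, so no order between them can be read. For the measured compounds named here, compound 2 differs from compound 1 in more than one place, and no step between measured compounds that differ in a single place is available.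

The unmeasured compound 3 `COc1ccc(S(=O)(=O)N2CCc3cccc(-c4ccc(C#N)cc4)c32)cc1` keeps the core of compound 1 and alters one group: cyano in place of dimethylamino on an aromatic carbon. With no measured step covering this change, the expectation rests only on the two numbers shown. Compound 3 is therefore expected to land near compound 1, the step of a 1.2-fold lower number from compound 1 to compound 3 (0.07 log units; within the scatter) estimated to stay within or only slightly beyond the scatter, in either direction. The estimate for compound 3 in this assay is 200 nM, within a range from 60 nM to 700 nM.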

Compound 3, half-maximal inhibitory concentration: 17.2 nM
Beside the measured number, compound 3's estimate is 12-fold (1.07 log units) above it, and the stated range ends above it.
By their numbers in this assay, from the lowest: compound 3; then compounds 2 and 1 (each within the scatter of the next).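

In this assay, the group on this aromatic carbon, para to a large group, proves decisive: going from 4-(dimethylamino)phenyl to 4-cyanophenyl on an unchanged core gives a large step (a 14-fold lower number from compound 1 to compound 3 (1.14 log units; beyond the scatter)), beyond the scatter. The earlier compounds shown here offered no single-place step, so they could not show that this position responds to a change at all. No measurement at hand explains the size of this step.

The compounds shown leave open how a carboxylic acid, a primary amide or a trifluoromethyl group at this place would stand against cyano in this assay. They also leave open whether cyano in place of dimethylamino would give a step of similar size on a core other than that of compound 1.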